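The source may hold more compounds than are shown below. What is called first, only, known or untested is meant among the compounds shown, and "the series" means these compounds.

Working notes on the series in a functional assay on HCT-116 cells (Homo sapiens) for antiproliferative activity, read by MTT assay, with a stated time of 48 h; a higher number here means a weaker inhibitor, a lower number a stronger inhibitor. Compound 1 `CCCCCC(CCO)n1cnc2c(N)nc(Cl)nc21` gives > 50000 nM, which is a limit of the assay and not a number. Compound 2 `CCCCCCCCC(CCO)n1cnc2c(Cl)nc(Cl)nc21` gives 22200 nM, and compound 3 `CCCCCCCCC(CCO)n1cnc2c(N)ncnc21` gives 11600 nM. For the measured compounds named here, these are the only two true numbers in the set, and they lie within the scatter of each other, so compound 3 cannot be separated from compound 2.

The next step leads to compound 4 `CCCCCCCCC(CCO)n1cnc2c(N)nc(Cl)nc21`, not yet measured, which carries chloro in place of hydrogen on an aromatic carbon, between two ring nitrogen atoms: chloro in place of hydrogen on an aromatic carbon. Going by the values given here, no measured pair isolates this change. In this assay, only a small step is therefore expected, probably not beyond the scatter and with no firm direction, starting from compound 3 at 11600 nM. The expected change is a 1.2-fold lower number from compound 3 to compound 4 (0.06 log units; within the scatter). For compound 4 the estimated value is 10000 nM, with an expected range of 3500 nM to 28000 nM.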

Compound 4, half-maximal inhibitory concentration: 21000 nM
For compound 4 the middle estimate is 2.1-fold (0.32 log units) below the measured one, and the stated range covers the measured number.
By their numbers in this assay, from the lowest: compounds 3, 4 and 2 (each within the scatter of the next). At a limit, above all of these: compound 1.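

In this assay, the position between two ring nitrogen atoms now has a matched pair, and chloro in place of hydrogen there gives a 1.8-fold higher number from compound 3 to compound 4 (0.26 log units; within the scatter), while amino in place of chloro on an aromatic carbon gives a 1.1-fold lower number from compound 2 to compound 4 (0.02 log units; within the scatter), so neither exchange separates the compounds. For the compounds shown here, the chain change, propyl in place of hydrogen on a saturated chain carbon, six bonds along the chain from an aromatic nitrogen, gives an at least 2.3-fold lower number from compound 1 to compound 4 (0.37 log units; beyond the scatter), the only step here beyond the scatter. Compound 1 stands at a limit and not at a number, so that step has no fixed size: the limit of > 50000 nM in this assay, at which 1 of the 4 values shown sits.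

From the compounds shown here alone, whether a different group at the position between two ring nitrogen atoms, such as an amine or a methyl group, would give a step beyond the scatter remains open. Also open, going by these compounds, is how a longer chain would read in this assay.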